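Trading a carboxy for a hydroxymethyl on the shared core

The source may report more compounds than this note shows. Statements on the series, on what has been measured and on what is new or still open speak of the compounds shown alone.

Of the compounds shown here, three built on the same fused two-ring core have been measured in a functional assay on PC-3 cells (Homo sapiens) for inhibition, read by colorimetric assay and MTT assay; a lower number here means a stronger inhibitor of growth, a higher number a weaker inhibitor of growth. Compound 1 `C=C/C(C)=C/C[C@H]1C(=C)CC[C@H]2[C@](C)(CO)CCC[C@]12C` gives 35000 nM in this assay. Compound 2 `C=CC(=C)[C@@H](C[C@H]1C(=C)CC[C@H]2[C@](C)(CO)CCC[C@]12C)OO` gives 34400 nM. Going by the values given here, the one measured step between them, a 1.0-fold lower number from compound 1 to compound 2 (0.01 log units; within the scatter), shows that exchanging the side chain left the number where it was.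

Compound 3 `C=CC(=C)[C@H](C[C@H]1C(=C)CC[C@@H]2[C@]1(C)CCC[C@@]2(C)C(=O)O)OO` stands apart: in this assay it gives only a limit, > 100000 nM, so no number is known for it (the limit of > 100000 nM in this assay, at which 1 of the 3 values shown sits). It carries a carboxy group on a saturated ring carbon of the core, where compounds 1 and 2 carry a hydroxymethyl.

Compound 4 `C=CC(=C)[C@H](C[C@H]1C(=C)CC[C@H]2[C@](C)(CO)CCC[C@]12C)OO` differs from compound 3 in exactly this place: hydroxymethyl in place of carboxy on a saturated ring carbon. Among the compounds with values here, no measured step covers this exchange directly. The step of a 1.0-fold lower number from compound 1 to compound 2 (0.01 log units; within the scatter) concerns the side chain, not the ring, and so says nothing about the direction of this change. What does bear on compound 4 is compound 2, which differs from it only in the arrangement at one chain carbon and gives 34400 nM in this assay. Compound 4 is therefore expected to land near that value, at an estimated 35000 nM, within 12000 nM to 100000 nM. The estimated step of an at least 2.8-fold lower number from compound 3 to compound 4 (0.45 log units; beyond the scatter) points toward a lower number than the limit seen for compound 3, though its size cannot be fixed.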

Compound 4, concentration for 50% growth inhibition: 50900 nM
Estimate against measurement, compound 4: 1.5-fold (0.16 log units) below, within the range that was stated.
By their numbers in this assay, from the lowest: compounds 2, 1 and 4 (each within the scatter of the next). At a limit, above all of these: compound 3.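

Compound 3 gives only a limit, so the first reading across this change is a floor and not a size: the limit of > 100000 nM in this assay, at which 1 of the 4 values shown sits. With hydroxymethyl in place of carboxy on this saturated ring carbon, the step is an at least 1.9-fold lower number from compound 3 to compound 4 (0.29 log units; that floor lies within the scatter), so the limit leaves room for a large gain or for very little, and the floor alone does not separate the two compounds. Among the compounds that carry the hydroxymethyl, neither the side chain nor the drawn configuration at the chain carbon gives a difference that can be told from the scatter, with a 1.5-fold higher number from compound 1 to compound 4 (0.16 log units; within the scatter) and a 1.5-fold higher number from compound 2 to compound 4 (0.17 log units; within the scatter), and the second of these comparisons is an especially clean one: the fact that compounds 2 and 4 differ only in the configuration as drawn.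

On these data alone, how much the carboxy really costs stays unknown as long as compound 3 has no number in this assay. The compounds shown also do not tell how a methyl ester, an aldehyde or an amine on this same saturated ring carbon would read, so only two groups at this position can be compared here, one of them through a limit.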